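Swapping 4-methoxyphenyl for 2-hydroxyethyl in the series

The source may hold more compounds than are shown below. What is called first, only, known or untested is meant among the compounds shown, and "the series" means these compounds.

In a functional assay on HepG2 cells (Homo sapiens) for antiproliferative activity, read by MTT assay, with a stated time of 72 h (on this read-out higher numbers stand for weaker inhibition and lower numbers for stronger inhibition), compound 1 `O=C1O[C@H]([C@@H](O)Cn2cc(-c3ccc(Br)cc3)nn2)C(OCc2ccccc2)=C1OCc1ccccc1` gives 5070 nM while compound 2 `O=C1O[C@H]([C@@H](O)Cn2cc(CCCCl)nn2)C(OCc2ccccc2)=C1OCc1ccccc1` gives 35000 nM and compound 3 `COc1ccc(-c2cn(C[C@H](O)[C@H]3OC(=O)C(OCc4ccccc4)=C3OCc3ccccc3)nn2)cc1` gives 46400 nM at the top of the range, level with compound 2. The small gap there is a 1.3-fold higher number from compound 2 to compound 3 (0.12 log units; within the scatter) within that pair, whereas a 9.2-fold higher number from compound 1 to compound 3 (0.96 log units; beyond the scatter) marks the clear separation from the bromo compound.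

Compound 4 `O=C1O[C@H]([C@@H](O)Cn2cc(CCO)nn2)C(OCc2ccccc2)=C1OCc1ccccc1` carries 2-hydroxyethyl in place of 4-methoxyphenyl on an aromatic carbon as 2-hydroxyethyl in place of 4-methoxyphenyl on an aromatic carbon. The other step away from the bromo compound, a 6.9-fold higher number from compound 1 to compound 2 (0.84 log units; beyond the scatter) with 3-chloropropyl entering, was also modest. Both modest steps start from a bromo compound, and compound 4 has no bromo group. The exchange of 3-chloropropyl and 4-methoxyphenyl stayed within the scatter, so a chain at this place has precedent. Within the data shown here, no other compound with 2-hydroxyethyl has been measured, which leaves the range wide.

No step beyond the scatter is expected in this assay for this change. The expected move is a 1.2-fold lower number from compound 3 to compound 4 (0.06 log units; within the scatter) on this estimate. Compound 4 is estimated at 40000 nM with a range from 15000 nM to 100000 nM as expected bounds.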

Compound 4, half-maximal inhibitory concentration: 68100 nM
Beside the measured number, compound 4's estimate is 1.7-fold (0.23 log units) below it, and the stated range covers the measured number.
By their numbers in this assay, from the lowest: compound 1; then compounds 2, 3 and 4 (each within the scatter of the next).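

In this assay, 2-hydroxyethyl, which has no ring, takes the place of 4-methoxyphenyl with no step beyond the scatter (a 1.5-fold higher number from compound 3 to compound 4 (0.17 log units; within the scatter)), so the six-membered aromatic ring is not enough on its own to separate these compounds. Hydroxy in place of chloromethyl on the chain also stays within the scatter (a 1.9-fold higher number from compound 2 to compound 4 (0.29 log units; within the scatter)), leaving compound 2, compound 3 and compound 4 level, while compound 1 goes against this with a large step (a 13-fold higher number from compound 1 to compound 4 (1.13 log units; beyond the scatter)). Nothing available explains why the 4-bromophenyl compound stands apart.

Open, on these data alone, is whether that separation needs the bromo group itself, which an unsubstituted phenyl or 4-chlorophenyl group would test. As far as these compounds go, how an amine or a carboxylic acid at the end of the chain would read is also open.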